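Pyrimidinyl substitution on the ether chain carbon of compound 3

The source may report more compounds than this note shows. Statements on the series, on what has been measured and on what is new or still open speak of the compounds shown alone.

Compound 3 `CCOc1cc2oc(=O)n(CCC(=O)O)c2cc1Cl` carries an ethoxy group on the shared core and gives 398 nM in an assay on HEK293 cells for inhibition of kynurenine 3-monooxygenase (Homo sapiens), read by LC-MS, with a stated time of 20 h; on this read-out lower numbers stand for stronger inhibition and higher numbers for weaker inhibition. Among the three measured compounds it holds the second highest number: compound 2 `O=C(O)CCn1c(=O)oc2cc(OCc3ccccn3)c(Cl)cc21`, with pyridin-2-yl on the saturated chain carbon bound to the ring oxygen and no methyl on that carbon, gives 5010 nM, and compound 1 `Cc1ccc([C@@H](C)Oc2cc3oc(=O)n(CCC(=O)O)c3cc2Cl)nc1`, with 5-methylpyridin-2-yl on that carbon, gives 6.31 nM. The two steps onto compound 3 run in opposite directions: a 13-fold lower number from compound 2 to compound 3 (1.10 log units; beyond the scatter) and a 63-fold higher number from compound 1 to compound 3 (1.80 log units; beyond the scatter).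

Compound 4 `C[C@@H](Oc1cc2oc(=O)n(CCC(=O)O)c2cc1Cl)c1ncccn1` differs from compound 3 by pyrimidin-2-yl in place of hydrogen on a saturated chain carbon bound to an oxygen on an aromatic ring and a saturated chain carbon. This is the carbon that carries 5-methylpyridin-2-yl in compound 1, so the step that bears on it is the reversal of a 63-fold higher number from compound 1 to compound 3 (1.80 log units; beyond the scatter), a large one. The step of a 13-fold lower number from compound 2 to compound 3 (1.10 log units; beyond the scatter) shows that a pyridin-2-yl on that carbon without the methyl does not give a low number; compound 4 keeps the methyl. A large step to a lower number in this assay is therefore expected. The ring in compound 4 is pyrimidin-2-yl and has no methyl on the ring, so the full size of the step back toward compound 1 is not assumed. Compound 4 is expected to give 25 nM (range 6 nM to 100 nM), an expected step of a 16-fold lower number from compound 3 to compound 4 (1.20 log units; beyond the scatter).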

Compound 4, half-maximal inhibitory concentration: 3160 nM
Compound 4: middle estimate off by 130-fold (2.10 log units), on the low side; measured number above the stated range.
By their numbers in this assay, from the lowest: compound 1; then compound 3; then compounds 4 and 2 (each within the scatter of the next).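

In this assay an aromatic ring on this saturated chain carbon does not by itself give a lower number: pyrimidin-2-yl in place of hydrogen goes the other way (a 7.9-fold higher number from compound 3 to compound 4 (0.90 log units; beyond the scatter)). Compound 2 left open whether the low number of compound 1 needed the methyl on this carbon, and compound 4 shows that the methyl alone does not suffice, so the ring group matters strongly at this position (a 500-fold higher number from compound 1 to compound 4 (2.70 log units; beyond the scatter)). Compound 4 and compound 2 cannot be ordered (a 1.6-fold lower number from compound 2 to compound 4 (0.20 log units; within the scatter)), and that step lies within the scatter although the two differ in both the ring and the methyl on the chain carbon.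

Pyrimidin-2-yl differs from 5-methylpyridin-2-yl in its ring atoms and in the methyl on the ring, and the compounds shown do not separate these two changes; 5-methylpyrimidin-2-yl on the same carbon would address that directly. No evidence on hand gives a reason for the number of compound 4.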